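A few compounds are considered here, and "the series" means these few. Any claim that something is new, unique, unknown or untested is made for them only; others in the source may bear on it.

Working notes on the series.

Among the compounds with values here, compound 1 `Cc1cc(Nc2cc(-c3ccccc3)[nH]n2)n2nc(SCc3ccc(F)cc3)nc2n1` sits second highest of the three numbers so far: in a functional assay on MCF7 cells (Homo sapiens) for inhibition, read by MTT assay, with a stated time of 72 h (on this read-out higher numbers stand for weaker inhibition and lower numbers for stronger inhibition), compound 1 gives 4020 nM. Its nearest neighbour is compound 2 `Cc1cc(Nc2cc(-c3ccccc3)[nH]n2)n2nc(SCc3ccc(Br)cc3)nc2n1`, which in this assay gives 2720 nM; the step of a 1.5-fold lower number from compound 1 to compound 2 (0.17 log units; within the scatter) stays within the scatter. Within the data shown here, compound 3 `Cc1cc(Nc2cc(-c3ccccc3)[nH]n2)n2nc(SCc3cccc4ccccc34)nc2n1` gives 7560 nM, and the step of a 1.9-fold higher number from compound 1 to compound 3 (0.27 log units; within the scatter) also stays within the scatter, while a 2.8-fold higher number from compound 2 to compound 3 (0.44 log units; beyond the scatter) is the only step so far that goes beyond it.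

The next compound, compound 4 `Cc1cc(Nc2cc(-c3ccccc3)[nH]n2)n2nc(SCC3CC3)nc2n1`, differs from compound 1 by cyclopropyl in place of 4-fluorophenyl on a saturated chain carbon bound to a sulfur. Among the measured compounds shown here, the steps that bear on it are those that alter the group on the saturated chain carbon bound to a sulfur, namely a 1.9-fold higher number from compound 1 to compound 3 (0.27 log units; within the scatter) and a 2.8-fold higher number from compound 2 to compound 3 (0.44 log units; beyond the scatter); both are small. For the measured compounds named here, no measured step replaces an aromatic group at this position with a non-aromatic one, so the change to cyclopropyl is outside the mapped ground. The expectation is therefore a step in this assay of modest size at most, more likely toward a higher number than a lower one.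

Compound 4 is estimated at 5500 nM, within 2200 nM to 14000 nM, which as a step from compound 1 means an expected 1.4-fold higher number from compound 1 to compound 4 (0.14 log units; within the scatter).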

Compound 4, half-maximal inhibitory concentration: > 50000 nM
Compound 4 gave a limit, no number; the forecaster's own chance of this, stated with the estimate: 10%; at least 9.0-fold (0.95 log units) between middle value and limit.
By their numbers in this assay, from the lowest: compounds 2, 1 and 3 (each within the scatter of the next, the first and the last beyond it). At a limit, above all of these: compound 4.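

The saturated chain carbon bound to a sulfur is less forgiving than the aromatic groups alone suggested. In this assay compound 4 stands at > 50000 nM, which is a limit of the assay and not a number. Cyclopropyl in place of the aromatic groups gives an at least 12-fold higher number from compound 1 to compound 4 (1.09 log units; beyond the scatter), an at least 18-fold higher number from compound 2 to compound 4 (1.26 log units; beyond the scatter) and an at least 6.6-fold higher number from compound 3 to compound 4 (0.82 log units; beyond the scatter), all beyond the scatter, and cyclopropyl is the only non-aromatic group shown here, while 4-fluorophenyl, 4-bromophenyl and naphthalen-1-yl all give measured numbers.

The compounds shown do not separate the loss of the aromatic ring from the change in ring size, and the limit leaves the true size of these steps open. As far as these compounds go, how cyclohexyl, a pyridine ring or a longer chain on this carbon would read also remains open.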